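A Halogenated Aryl Swap on the Sulfonamide Nitrogen

The compounds below may be only part of what the source reports. "The series", "measured", "known", "first", "only" and "open" are said of these compounds alone.

Going by the values given here, in a functional assay on MCF7 cells (Homo sapiens) for inhibition, read by CCK-8 assay, with a stated time of 72 h (on this read-out higher numbers stand for weaker inhibition and lower numbers for stronger inhibition), compound 2 `CC(C)(C)c1ccc(NS(=O)(=O)c2cccc(CCCCCCNC(=O)/C=C/c3cccnc3)c2)cc1` gives 26.3 nM, the highest of the two numbers measured so far; its nearest neighbour, compound 1 `Cc1cccc(NS(=O)(=O)c2cccc(CCCCCCNC(=O)/C=C/c3cccnc3)c2)c1`, gives 4 nM in this assay. Among the compounds with values here, the only step on record, a 6.6-fold higher number from compound 1 to compound 2 (0.82 log units; beyond the scatter), shows that the aryl group on the sulfonamide nitrogen moves the read-out in this assay by a modest amount beyond the scatter. Compound 3 `O=C(/C=C/c1cccnc1)NCCCCCCc1cccc(S(=O)(=O)Nc2ccc(F)c(Cl)c2)c1` changes that same position again: 3-chloro-4-fluorophenyl in place of 4-(tert-butyl)phenyl on a sulfonamide nitrogen. Within the data shown here, no measured pair contains this new group, so its direction is not fixed by the data; the one step on record bears on it only by showing that this position is sensitive. The author expects compound 3 to return a number between the two measured ones, with the step of a 2.9-fold lower number from compound 2 to compound 3 (0.47 log units; beyond the scatter) to compound 3 estimated in this assay. Compound 3 is estimated at 9 nM, within 2.5 nM to 35 nM.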

Compound 3, half-maximal inhibitory concentration: 6.3 nM
Compound 3: the middle estimate sits 1.4-fold (0.15 log units) above what was measured; the range from low to high includes it.
By their numbers in this assay, from the lowest: compounds 1 and 3 (each within the scatter of the next); then compound 2.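

In this assay the new step reads a 4.2-fold lower number from compound 2 to compound 3 (0.62 log units; beyond the scatter) and shows that a halogenated aryl group on the sulfonamide nitrogen also moves the read-out beyond the scatter, here toward lower numbers. The second step reads a 1.6-fold higher number from compound 1 to compound 3 (0.20 log units; within the scatter) and places 3-chloro-4-fluorophenyl level with 3-methylphenyl, so among these three compounds only 4-(tert-butyl)phenyl stands apart, and the position tolerates two differently substituted aryl groups with no difference that can be read. Nothing available explains why these groups give these numbers.

The compounds shown leave open whether 3-chlorophenyl or 4-fluorophenyl alone would give a number like that of compound 3. They also leave open how a cyclohexyl group on the sulfonamide nitrogen, with no aromatic ring at all, would read.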